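The source may hold more compounds than are shown below. What is called first, only, known or untested is meant among the compounds shown, and "the series" means these compounds.

Compound 3, with the structure `COc1cc(C(=O)/C=C/c2ccc(OCCCNCCCN)cc2)cc(OC)c1OC`, gives 13700 nM in a functional assay on HT-29 cells (Homo sapiens) for antiproliferative activity, read by MTT assay, with a stated time of 48 h; a lower number here means a stronger inhibitor, a higher number a weaker inhibitor. Of the two numbers reported, this is the higher one, although its nearest neighbour is compound 2, structure `COc1cc(C(=O)/C=C/c2ccc(OCCCNCCCNCCCCN)cc2)cc(OC)c1OC`, whose value of 10800 nM is within the scatter of it: a 1.3-fold higher number from compound 2 to compound 3 (0.10 log units; within the scatter). Compound 1, structure `COc1cc(C(=O)/C=C/c2ccc(OCCCNCCCNCCCCNCCCN)cc2)cc(OC)c1OC`, reaches only (the limit of > 40000 nM in this assay, at which 1 of the 3 values shown sits), so its value of > 40000 nM is a limit of this assay and not a number.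

The unmeasured compound 4, structure `COc1cc(C(=O)/C=C/c2ccc(OCCCNCCCCN)cc2)cc(OC)c1OC`, differs from compound 3 in one place: aminomethyl in place of amino on a saturated chain carbon, three bonds along the chain from an amine nitrogen. The measured steps all remove or add a whole chain segment on an amine nitrogen rather than lengthening a chain by one carbon. Removing a segment from compound 1 gave an at least 3.7-fold lower number from compound 1 to compound 2 (0.56 log units; beyond the scatter) and an at least 2.9-fold lower number from compound 1 to compound 3 (0.46 log units; beyond the scatter), both beyond the scatter, whereas the shorter step a 1.3-fold higher number from compound 2 to compound 3 (0.10 log units; within the scatter) stayed within it. None of these steps matches a one-carbon extension, so no change beyond the scatter is expected for compound 4 in this assay: a 1.1-fold lower number from compound 3 to compound 4 (0.06 log units; within the scatter). Compound 4 is therefore estimated at 12000 nM, with a range from 5000 nM to 30000 nM.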

Compound 4, half-maximal inhibitory concentration: 20200 nM
For compound 4 the middle estimate is 1.7-fold (0.23 log units) below the measured one; the measured number falls inside the stated range.
By their numbers in this assay, from the lowest: compounds 2, 3 and 4 (each within the scatter of the next). At a limit, above all of these: compound 1.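

In this assay, aminomethyl in place of amino on a saturated chain carbon, three bonds along the chain from an amine nitrogen, is the first one-carbon extension among these compounds, and it stays within the scatter: a 1.5-fold higher number from compound 3 to compound 4 (0.17 log units; within the scatter). The same holds when the chain is shortened by a larger piece, a 1.9-fold higher number from compound 2 to compound 4 (0.27 log units; within the scatter), so the three measured numbers cannot be put in order and the one-carbon change shows no effect on the read-out. The step that rests on the limit of compound 1 gives only a floor, an at least 1.9-fold lower number from compound 1 to compound 4 (0.29 log units; that floor lies within the scatter), and that floor, which lies within the scatter, does not separate the two: the limit of > 40000 nM in this assay, at which 1 of the 4 values shown sits.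

The compounds shown leave open whether a hydroxyl or a carboxylic acid in place of the end amine would move the number beyond the scatter. They also leave open how a 5-aminopentyl chain on the amine nitrogen would read in this assay, and whether a one-carbon extension would stay within the scatter on the longer chains of compound 1 and compound 2.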